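One more methoxy on compound 2

The source may hold more compounds than are shown below. What is called first, only, known or untested is meant among the compounds shown, and "the series" means these compounds.

Going by the values given here, in an ADME assay on K562 cells (Homo sapiens) for cytotoxicity, with a stated time of 72 h (on this read-out lower numbers stand for stronger inhibition and higher numbers for weaker inhibition), none of the three compounds tested so far has given a number. Compound 1 (`COc1ccc(CNc2ncnc3c2ncn3C2CCCCO2)cc1`) shows > 100000 nM as a limit of the assay. Compound 2 (`COc1ccc(CNc2ncnc3c2ncn3C2CCCCO2)cc1OC`) shows > 100000 nM as a limit too, so its standing is known only as a limit. Compound 3 (`COc1ccc(CNc2ncnc3c2ncn3C2CCCCO2)c(OC)c1OC`) likewise shows > 37500 nM as a limit.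

Compound 4 (`COc1cc(CNc2ncnc3c2ncn3C2CCCCO2)cc(OC)c1OC`) has not yet been measured. The structural change that leads to it from compound 2 is this: (methoxy in place of hydrogen on an aromatic carbon), a methoxy in place of hydrogen on an aromatic carbon.

Two measured steps make the same kind of exchange: a step that the two limits leave unreadable from compound 1 to compound 2 and a step that the two limits leave unreadable from compound 2 to compound 3. Neither offers a size to carry over. What remains is where the compounds sit: compound 1 and compound 2 share (the limit of > 100000 nM in this assay, at which 2 of the 3 values shown sit), while compound 3 sits at the limit of > 37500 nM in this assay, at which 1 of the 3 values shown sits. With no measured number in the series, no clear step in either direction is expected in this assay, and weak inhibition is the likely outcome. The expected move is an at least 1.2-fold lower number from compound 2 to compound 4 (0.09 log units; that floor lies within the scatter) in this reading. For compound 4 the estimated value is 80000 nM with an expected range from 30000 nM to 200000 nM in this assay.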

Compound 4, half-maximal inhibitory concentration: > 100000 nM
Compound 4 gave a limit, no number; the forecaster's own chance of this, stated with the estimate: 75%; middle value at least 1.2-fold (0.09 log units) from the limit.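

Compound 2 and compound 4 both give only limits of the assay, not numbers, so no size can be read for the step between them. The compounds shown leave open whether the added methoxy changes the read-out at all in this assay, and how far any of these compounds lies beyond its limit.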